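Moving the chlorine on a pyridinyl ether

A few compounds are considered here, and "the series" means these few. Any claim that something is new, unique, unknown or untested is made for them only; others in the source may bear on it.

Compound 1 `Cn1c(COc2cccc(C(=O)O)c2)nc2ccc(Oc3ccc(F)cc3)nc21` gives 1.5 in a physicochemical assay for lipophilicity, read by LC-MS, in phosphate buffer, measured as octanol-water partition, with a stated time of 30 min, at pH 7.4, tested at 200 mM; on this read-out lower numbers stand for lower lipophilicity and higher numbers for higher lipophilicity.
Compound 2 `Cc1ccc(Oc2cc3c(cn2)nc(COc2cccc(C(=O)O)c2)n3C)cc1` gives 1 in this assay.
Compound 3 `Cn1c(COc2cccc(C(=O)O)c2)nc2ccc(Oc3cccc(Cl)n3)cc21` gives 1.2 in this assay.

Among the three measured compounds, the number for compound 3 lies between those of compound 1 and compound 2, and its gaps to both fall within the usual scatter of repeated measurements, so the three cannot be told apart on this read-out. Compound 4 `Cn1c(COc2cccc(C(=O)O)c2)nc2ccc(Oc3cc(Cl)ccn3)cc21` has not yet been measured in this assay. It differs from compound 3 in one place (4-chloropyridin-2-yl in place of 6-chloropyridin-2-yl on an oxygen on an aromatic ring), that is, 4-chloropyridin-2-yl in place of 6-chloropyridin-2-yl on an oxygen on an aromatic ring. The two share the same atoms, joined differently. No step between measured compounds covers such a change, so there is nothing in the shown numbers to suggest a shift beyond the scatter in either direction. Compound 4 is therefore expected to give about 1.2 in this assay, between 0.8 and 1.6. The expected step of no change at the digits printed from compound 3 to compound 4 (within the scatter) is estimated to be no larger than the scatter.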

Compound 4, distribution coefficient: 1.2
For compound 4 middle estimate and measured number coincide at the digits printed, within the range that was stated.
By their numbers in this assay, from the lowest: compounds 2, 3, 4 and 1 (each within the scatter of the next, the first and the last beyond it).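

Among the compounds shown here, this pair gives the first reading of a single change at this place, on an oxygen on an aromatic ring, since compounds 1, 2 and 3 differ from one another in more than one place and offered no such step. In this assay, 4-chloropyridin-2-yl in place of 6-chloropyridin-2-yl gives no change at the digits printed from compound 3 to compound 4 (within the scatter). For this one pair, then, with the same atoms joined differently, the two chloropyridinyl groups cannot be told apart on this read-out, though a single pair sets no rule for other changes at this place.

As far as these compounds go, whether a group with other atoms, such as an amine or a longer chain in place of 4-chloropyridin-2-yl, would give a step beyond the scatter remains open. Nothing shown offers an explanation for the result with compound 4.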